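The source may report more compounds than this note shows. Statements on the series, on what has been measured and on what is new or still open speak of the compounds shown alone.

Compound 2 `CCn1c(C(=O)N[C@@H](C)CO)ccc1C(CC)(CC)c1ccc(OCS(=O)(=O)c2ccccc2)c(C)c1` is one of three compounds with a shared core tested in a functional assay on PC-3 cells (Homo sapiens) for antiproliferative activity, read by MTT assay, with a stated time of 24 h; on this read-out higher numbers stand for weaker inhibition and lower numbers for stronger inhibition. Compound 2 gives 9520 nM, the lower of the two numbers shown. Compound 3 `CCn1c(C(=O)NC(C)(C)CO)ccc1C(CC)(CC)c1ccc(OCS(=O)(=O)c2ccccc2)c(C)c1` gives 9850 nM. The gap between them is a 1.0-fold higher number from compound 2 to compound 3 (0.01 log units; within the scatter). Compound 1 `CCn1c(C(=O)N[C@H](C)C(=O)OC)ccc1C(CC)(CC)c1ccc(OCS(=O)(=O)c2ccccc2)c(C)c1` gives only the assay limit > 50000 nM. From there the two measured steps are an at least 5.2-fold lower number from compound 1 to compound 2 (0.72 log units; beyond the scatter) and an at least 5.0-fold lower number from compound 1 to compound 3 (0.70 log units; beyond the scatter). Compound 4 `CCn1c(C(=O)NC2(C(=O)O)CC2)ccc1C(CC)(CC)c1ccc(OCS(=O)(=O)c2ccccc2)c(C)c1` differs from compound 2 by 1-carboxycyclopropyl in place of 1-(hydroxymethyl)ethyl on an amide-type nitrogen. For the measured compounds named here, no measured step puts 1-carboxycyclopropyl in this place, so the steps from compound 1 bear on it only loosely. Compound 4 is therefore expected to show a higher number, a 2.3-fold higher number from compound 2 to compound 4 (0.36 log units; beyond the scatter), with a real chance of only a limit. The estimate for compound 4 is 22000 nM, between 7000 nM and 70000 nM.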

Compound 4, half-maximal inhibitory concentration: 26300 nM
Estimate against measurement, compound 4: 1.2-fold (0.08 log units) below; measured number inside the range.
By their numbers in this assay, from the lowest: compounds 2 and 3 (each within the scatter of the next); then compound 4. At a limit, above all of these: compound 1.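

On the amide-type nitrogen, the hydroxymethyl groups and 1-carboxycyclopropyl can be compared directly: there is a 2.8-fold higher number from compound 2 to compound 4 (0.44 log units; beyond the scatter) and a 2.7-fold higher number from compound 3 to compound 4 (0.43 log units; beyond the scatter) when the carboxylic acid on a three-membered ring enters. The acid-bearing compound 4 therefore keeps a measured number, though a modestly higher one than either alcohol. Compound 1 stands at a limit of the assay: the limit of > 50000 nM in this assay, at which 1 of the 4 values shown sits. Set against that limit, there is an at least 1.9-fold lower number from compound 1 to compound 4 (0.27 log units; that floor lies within the scatter). Going by these compounds, this change brings in the ring and the acid together, so their separate shares remain unknown. 1-Carboxyethyl, with the acid and no ring, or 1-(hydroxymethyl)cyclopropyl, with the ring and no acid, would tell them apart.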